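Furan-2-yl in place of the bicyclic group at the eight-position

A few compounds are considered here, and "the series" means these few. Any claim that something is new, unique, unknown or untested is made for them only; others in the source may bear on it.

The series shares one core, varied on an aromatic carbon of the five-membered ring with 2 nitrogen, part of a fused or bridged system of two rings, between two ring nitrogen atoms. Compound 1 `CCCn1c(=O)c2nc(C(O)(CC)CC)[nH]c2n(CCC)c1=O` carries a non-ring group with one oxygen there and gives 170 nM in an assay on cell membranes for binding affinity to adenosine receptor A1 (Cavia porcellus), read by radioligand binding; a higher number here means a weaker inhibitor, a lower number a stronger inhibitor. Compound 2 `CCCn1c(=O)c2nc([C@H]3CC4C=CC3C4)[nH]c2n(CCC)c1=O` gives 3.4 nM and compound 3 `CCCn1c(=O)c2nc([C@@H]3CC4CCC3C4)[nH]c2n(CCC)c1=O` gives 3.8 nM in this assay; the two are within the scatter of each other (a 1.1-fold higher number from compound 2 to compound 3 (0.05 log units; within the scatter)), and both lie far below compound 1 (a 50-fold lower number from compound 1 to compound 2 (1.70 log units; beyond the scatter); a 45-fold lower number from compound 1 to compound 3 (1.65 log units; beyond the scatter)). Compound 3 thus stands with compound 2 at the low end of the three numbers.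

Compound 4 `CCCn1c(=O)c2nc(-c3ccco3)[nH]c2n(CCC)c1=O` has not been measured. The change is a group of 5 heavy atoms (4 carbon, 1 oxygen; one five-membered aromatic ring with 1 hetero atom) in place of a group of 7 heavy atoms (7 carbon; 2 five-membered non-aromatic rings of carbon only), on an aromatic carbon. Among the compounds with values here, no measured step exchanges the two five-membered non-aromatic rings for an aromatic ring, so the measured steps only frame the question: a ring group gave low numbers, a non-ring oxygen-bearing group a high one. Furan-2-yl is a ring yet brings an oxygen acceptor, so compound 4 is expected to sit between these, with a step of an 11-fold higher number from compound 3 to compound 4 (1.02 log units; beyond the scatter). The estimate for compound 4 in this assay is 40 nM, within 8 nM to 200 nM.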

Compound 4, inhibition constant: 560 nM
Estimate against measurement, compound 4: 14-fold (1.15 log units) below; the whole stated range lies below it.
By their numbers in this assay, from the lowest: compounds 2 and 3 (each within the scatter of the next); then compound 1; then compound 4.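

In this assay furan-2-yl on this aromatic carbon sits far above both bicyclic groups (a 150-fold higher number from compound 3 to compound 4 (2.17 log units; beyond the scatter)) and (a 160-fold higher number from compound 2 to compound 4 (2.22 log units; beyond the scatter)), so a ring at this place does not by itself go with a low number. Within the data shown here, it also stands above the non-ring 1-ethyl-1-hydroxypropyl group in a modest step (a 3.3-fold higher number from compound 1 to compound 4 (0.52 log units; beyond the scatter)), which places compound 4 at the high end of the four compounds and undoes the ring versus non-ring reading that the earlier compounds allowed. Nothing measured on these compounds accounts for these steps.

Open, as far as these compounds go, is whether a phenyl or a cyclopentyl group at this position would stay with the low numbers of compound 2 and compound 3 or move toward compound 4. Thiophen-2-yl, with sulfur in place of the furan oxygen, would separate the effect of that oxygen from that of the aromatic ring.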